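Aryl swap from compound 3 to compound 4

The compounds below may be only part of what the source reports. "The series", "measured", "known", "first", "only" and "open" are said of these compounds alone.

Compound 1 `COc1cc(C(=O)c2sc(-c3ccc(Cl)c(Cl)c3)cc2N)cc(OC)c1OC` gives 290 nM
Compound 2 `COc1cc(C(=O)c2sc(-c3ccsc3)cc2N)cc(OC)c1OC` gives 9.6 nM
Compound 3 `COc1cc(C(=O)c2sc(-c3ccc(F)cc3)cc2N)cc(OC)c1OC` gives 15 nM

All three values come from a functional assay on CCRF-CEM cells (Homo sapiens) for antiproliferative activity (on this read-out lower numbers stand for stronger inhibition and higher numbers for weaker inhibition), and the compounds differ only in one aryl group on the shared core. Compound 3 stands second highest of the three numbers, but its gap on one side is only a 1.6-fold higher number from compound 2 to compound 3 (0.19 log units; within the scatter) while the other side shows a 19-fold lower number from compound 1 to compound 3 (1.29 log units; beyond the scatter) in the data. Compound 4 `COc1cccc(-c2cc(N)c(C(=O)c3cc(OC)c(OC)c(OC)c3)s2)c1` has 3-methoxyphenyl in place of 4-fluorophenyl on an aromatic carbon next to the ring sulfur (3-methoxyphenyl in place of 4-fluorophenyl on an aromatic carbon). All measured steps fall at this same carbon. The position can respond strongly, as a 30-fold lower number from compound 1 to compound 2 (1.48 log units; beyond the scatter) shows, yet both large steps start from the 3,4-dichlorophenyl group of compound 1. Going by the values given here, no measured compound carries a methoxy group, so the evidence for this change is indirect. In this assay a small rise is expected, possibly not beyond the scatter. The expected change is a 2.0-fold higher number from compound 3 to compound 4 (0.30 log units; within the scatter) as an estimate. Compound 4 is estimated at 30 nM with an expected range of 10 nM to 100 nM overall.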

Compound 4, half-maximal inhibitory concentration: 16 nM
For compound 4 the middle estimate is 1.9-fold (0.27 log units) above the measured one, and the stated range covers the measured number.
By their numbers in this assay, from the lowest: compounds 2, 3 and 4 (each within the scatter of the next); then compound 1.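

In this assay, 3-methoxyphenyl on the aromatic carbon next to the ring sulfur behaves like the two smaller-gap groups, with a 1.1-fold higher number from compound 3 to compound 4 (0.03 log units; within the scatter) and a 1.7-fold higher number from compound 2 to compound 4 (0.22 log units; within the scatter) as steps that both lie within the scatter. The series thus holds three different groups at this carbon at one level, and the 3,4-dichlorophenyl group stands apart, with an 18-fold lower number from compound 1 to compound 4 (1.26 log units; beyond the scatter) as a third large step that again starts from compound 1. Nothing measured on these compounds explains either the shared level or the gap to compound 1.

Whether that gap follows from one chlorine or from both stays open, with no 4-chlorophenyl or 3-chlorophenyl group among the compounds shown. Also open, as far as these compounds go, is how this carbon responds to an aryl group carrying an amine or a carboxylic acid.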